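Swapping benzamido for nitro on a weak growth inhibitor

The source may report more compounds than this note shows. Statements on the series, on what has been measured and on what is new or still open speak of the compounds shown alone.

- compound 1 `O=C(CCC1=CCCN(Cc2ccc(F)cc2)C1=O)NO`: "not determined" (no result reported)
- compound 2 `COc1ccc(CN2CCC=C(CCC(=O)NO)C2=O)cc1`: "not determined" (no result reported)
- compound 3 `O=C(CCC1=CCCN(Cc2ccc(NC(=O)c3ccccc3)cc2)C1=O)NO`: > 10000 nM

Within the data shown here, only one of these three compounds has any reading in a functional assay on NUGC-3 cells (Homo sapiens) for inhibition, read by sulforhodamine B assay (on this read-out lower numbers stand for stronger inhibition of growth and higher numbers for weaker inhibition of growth), and that reading is not an exact number. Compound 3 gives > 10000 nM, which is a limit of the assay. Among the measured compounds shown here, this leaves no measured pair of compounds to show how much a change on this part of the structure can matter.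

The next compound to be tested is compound 4 `O=C(CCC1=CCCN(Cc2ccc([N+](=O)[O-])cc2)C1=O)NO`. It keeps the rest of compound 3 and carries nitro in place of benzamido on an aromatic carbon. This removes a whole aromatic ring along with the amide link, so the change is not a small one on paper.

With so little to go on, only a modest shift toward stronger inhibition of growth is expected in this assay, and a result that again reaches the limit would be no surprise. The expected change is an at least 1.2-fold lower number from compound 3 to compound 4 (0.09 log units; that floor lies within the scatter). For compound 4 the estimated value is 8000 nM, with an expected range from 2000 nM to 20000 nM.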

Compound 4, concentration for 50% growth inhibition: 1110 nM
For compound 4 the middle estimate is 7.2-fold (0.86 log units) above the measured one, outside the stated range (below it).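

In this assay compound 3 gives > 10000 nM, which is a limit of the assay and not an exact number. Nitro in place of benzamido gives an at least 9.0-fold lower number from compound 3 to compound 4 (0.95 log units; beyond the scatter), the first sign that the group on this aromatic carbon can strongly change growth inhibition, even though the rest of the structure stays the same. Only the smallest possible size of this step can be read, and its true size remains unknown: the limit of > 10000 nM in this assay, at which 1 of the 4 values shown sits.

One step cannot show whether the stronger inhibition comes from losing the benzamido group or from gaining the nitro group. An amine or a carboxylic acid on the same aromatic carbon would help to separate these two possibilities, and no trend across groups at this position can yet be stated.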